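Swapping a Methoxyphenyl for a Hydroxyphenyl on Two Cores

A few compounds are considered here, and "the series" means these few. Any claim that something is new, unique, unknown or untested is made for them only; others in the source may bear on it.

Compound 2 `COc1ccccc1-c1cn(C[C@H](O)[C@H]2OC(=O)C(OCc3ccccc3)=C2OCc2ccccc2)nn1` and compound 1 `O=C1O[C@H]([C@@H](O)Cn2cc(-c3cccc(O)c3)nn2)C(OCc2ccccc2)=C1OCc1ccccc1` share one core and differ in a single place: 3-hydroxyphenyl in place of 2-methoxyphenyl on an aromatic carbon. In a functional assay on HepG2 cells (Homo sapiens) for antiproliferative activity, read by MTT assay, with a stated time of 72 h (a higher number here means a weaker inhibitor, a lower number a stronger inhibitor), compound 2 gives only a limit, > 100000 nM, not a number. Compound 1 gives 62700 nM in this assay. The measured step is an at least 1.5-fold lower number from compound 2 to compound 1 (0.20 log units; that floor lies within the scatter), and its floor is set because of the limit of > 100000 nM in this assay, at which 2 of the 3 values shown sit.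

Compound 3 `COc1ccccc1-c1cn(C/C=C2\OC(=O)C(OCc3ccccc3)=C2OCc2ccccc2)nn1` carries a different core; the difference between the two cores is not broken down here. In this assay compound 3 also gives only a limit, > 100000 nM. Compound 4 `O=C1O/C(=C\Cn2cc(-c3cccc(O)c3)nn2)C(OCc2ccccc2)=C1OCc1ccccc1` is compound 3 with the same change made: 3-hydroxyphenyl in place of 2-methoxyphenyl on an aromatic carbon.

The expectation for compound 4 rests on compound 1 and compound 2, where the same change gave an at least 1.5-fold lower number from compound 2 to compound 1 (0.20 log units; that floor lies within the scatter), a move from a limit to a number that stays far up the scale. The expected step is therefore a modest one, an at least 1.4-fold lower number from compound 3 to compound 4 (0.15 log units; that floor lies within the scatter). Compound 4 is expected to give about 70000 nM in this assay, most likely between 30000 nM and 150000 nM.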

Compound 4, half-maximal inhibitory concentration: 61700 nM
Estimate against measurement, compound 4: 1.1-fold (0.05 log units) above; the measured number falls inside the stated range.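

On the second core, the change from 2-methoxyphenyl to 3-hydroxyphenyl gives an at least 1.6-fold lower number from compound 3 to compound 4 (0.20 log units; that floor lies within the scatter) in this assay and so repeats what was seen on the first core, where a limit also gave way to a number: the same change on two cores in this assay, an at least 1.5-fold lower number (0.20 log units; that floor lies within the scatter) from compound 2 to compound 1 and an at least 1.6-fold lower number (0.20 log units; that floor lies within the scatter) from compound 3 to compound 4; the limit leaves it open whether they differ. The true size of neither step can be read, only its floor, because each starting compound stands at a limit rather than at a number: the limit of > 100000 nM in this assay, at which 2 of the 4 values shown sit. The two pairs therefore show that the change can be carried to the other core with the same kind of result, but they do not show that its size is the same on both cores, nor that it is larger than the usual scatter.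

The change also alters both the group and its place on the ring, so the compounds shown leave open which of the two matters. A 3-methoxyphenyl or a 2-hydroxyphenyl group could separate them, and a 3-aminophenyl group could test whether another group in that place gives a different result.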